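A few compounds are considered here, and "the series" means these few. Any claim that something is new, unique, unknown or untested is made for them only; others in the source may bear on it.

The measured compounds:

Compound 1 `CCCCCCNc1nc(SCc2ccc(C(F)(F)F)cc2)nc2ccccc12` gives in a functional assay on MCF7 cells (Homo sapiens) for cytotoxicity, read by MTT assay, with a stated time of 72 h (on this read-out higher numbers stand for weaker inhibition and lower numbers for stronger inhibition), a value of 24300 nM.
Compound 2 `FC(F)(F)c1ccc(CSc2nc(N3CCCCC3)c3ccccc3n2)cc1` reaches in this assay only the limit of the assay, > 50000 nM.
Compound 3 `CCOc1ccccc1Nc1nc(SCc2ccc(C(F)(F)F)cc2)nc2ccccc12` reaches in this assay only the limit of the assay, > 50000 nM.

Compound 3 therefore stands at the weak end of what was measured, with no number of its own, only a limit; it shares that position with compound 2, as the limit of > 50000 nM in this assay, at which 2 of the 3 values shown sit, shows. Compound 4 `FC(F)(F)c1ccc(CSc2nc(Nc3cccc(Cl)c3)c3ccccc3n2)cc1` keeps the shared core and changes only the group on the ring nitrogen: 3-chlorophenyl in place of 2-ethoxyphenyl on a nitrogen on an aromatic ring.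

Among the measured compounds shown here, two measured steps touch compound 3. The step of an at least 2.0-fold higher number from compound 1 to compound 3 (0.31 log units; beyond the scatter) replaced a hexyl chain by an aromatic group; the step that the two limits leave unreadable from compound 2 to compound 3 cannot be read because both ends are limits. For the measured compounds named here, neither step tests a swap of one aromatic group for another, so no measured step bears directly on the change to compound 4. The expected step of an at least 1.1-fold lower number from compound 3 to compound 4 (0.04 log units; that floor lies within the scatter) is therefore no change beyond the scatter. Compound 4 is estimated at 45000 nM, within a range from 15000 nM to 150000 nM, and most likely it again reports only a limit.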

Compound 4, half-maximal inhibitory concentration: 25100 nM
Compound 4: the middle estimate sits 1.8-fold (0.25 log units) above what was measured, and the stated range covers the measured number.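

Replacing 2-ethoxyphenyl with 3-chlorophenyl on the ring nitrogen gives an at least 1.9-fold lower number from compound 3 to compound 4 (0.29 log units; that floor lies within the scatter), and changing the whole amino group gives an at least 1.9-fold lower number from compound 2 to compound 4 (0.29 log units; that floor lies within the scatter). The real size of these two steps stays unknown because the weaker end of each is only a limit: the limit of > 50000 nM in this assay, at which 2 of the 4 values shown sit.

Compared with the hexyl compound, the result is a 1.0-fold higher number from compound 1 to compound 4 (0.01 log units; within the scatter), so an aromatic group on this nitrogen can sit level with a hexyl chain, something compound 3 alone did not suggest, and compound 3 remains the case that goes against this.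

With only these two aromatic groups, the compounds cannot separate the gain of the chlorine from the loss of the ethoxy group. On these data alone, how a plain phenyl ring or a benzyl group would behave at this nitrogen remains open.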